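Furan for pyridine on the aryl end of the series

This account rests on a few compounds, and the source may have more. Where it says the series, first, only, none or still open, it means among the compounds named here.

Values in a functional assay on A-375 cells (Homo sapiens) for activation, with a stated time of 3 days; a lower number here means that less compound is needed, a higher number that more compound is needed for the effect:
- Compound 1 `O=C(Nc1ccc(-c2cscn2)cc1)C1CCCN(C(=O)c2ccc(F)c(F)c2)C1`: > 20000 nM (a limit)
- Compound 2 `O=C(Nc1ccc(-c2cscn2)cc1)C1CCCN(Cc2ccc3cn[nH]c3c2)C1`: > 20000 nM (a limit)
- Compound 3 `O=C(Nc1ccc(-c2ccncc2)cc1)C1CCCN(Cc2ccc(F)c(F)c2)C1`: 1180 nM

For the measured compounds named here, compound 3 gives the only number here, 1180 nM. The other two results are limits. Compound 4 `O=C(Nc1ccc(-c2ccco2)cc1)C1CCCN(Cc2ccc(F)c(F)c2)C1` carries furan-2-yl in place of pyridin-4-yl on an aromatic carbon, para to a large group (furan-2-yl in place of pyridin-4-yl on an aromatic carbon).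

Going by the values given here, the sole measured step, a step that the two limits leave unreadable from compound 1 to compound 2, concerns an amine nitrogen in a ring and does not touch this place. The remaining evidence is the limit of > 20000 nM in this assay, at which 2 of the 3 values shown sit. The size of the change therefore stays poorly defined, with a modest shift towards more compound needed expected only tentatively.

The expected change is a 2.5-fold higher number from compound 3 to compound 4 (0.41 log units; beyond the scatter). For compound 4 the estimated value is 3000 nM, with an expected range of 700 nM to 15000 nM.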

Compound 4, half-maximal effective concentration: 2200 nM
Compound 4: the middle estimate sits 1.4-fold (0.13 log units) above what was measured, and the stated range covers the measured number.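

In this assay, furan-2-yl in place of pyridin-4-yl gives a 1.9-fold higher number from compound 3 to compound 4 (0.27 log units; within the scatter). On this aromatic carbon, para to a large group, a five-membered aromatic ring with an oxygen therefore reads the same as a six-membered aromatic ring with a nitrogen, so the pyridine nitrogen is not needed for a measurable value. This is the only readable step shown, and the first at this place.

Going by these compounds, how an amine or a carboxylic acid on this aromatic carbon would read stays open. The other step cannot be read, and few comparisons are available: the limit of > 20000 nM in this assay, at which 2 of the 4 values shown sit.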